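The source may report more compounds than this note shows. Statements on the series, on what has been measured and on what is new or still open speak of the compounds shown alone.

Compound 1 `Cc1c(OCCCCOc2ccc(C(=O)O)cc2Cl)ccc(C(=O)CC(C)C)c1O`: in an assay on HEK293 cells for positive allosteric modulation of metabotropic glutamate receptor 2 (Rattus norvegicus), read by thallium flux, with a stated time of 2.5 min (a lower number here means that less compound is needed, a higher number that more compound is needed for the effect), compound 1 gives 96 nM
Compound 2 `CCC(=O)c1ccc(OCCCCOc2ccc(F)c(C(=O)O)c2)c(C)c1O`: in this assay compound 2 gives 124 nM

These two values lie within the usual scatter of each other, so compound 2 cannot be set apart from compound 1 on these numbers. Compound 3 `Cc1c(OCCCCOc2ccc(F)c(C(=O)O)c2)ccc(C(=O)CC(C)C)c1O` is compound 2 with isopropyl in place of methyl on a saturated chain carbon bound to a carbonyl carbon. For the measured compounds named here, no measured pair shows this change alone; compound 1 carries the same isobutylcarbonyl group on a different remainder of the molecule. Compound 3 is expected to show a step of a 1.2-fold lower number from compound 2 to compound 3 (0.09 log units; within the scatter), nothing beyond the scatter. Compound 3 is estimated at 100 nM, between 40 nM and 250 nM.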

Compound 3, half-maximal effective concentration: 153 nM
For compound 3 the middle estimate is 1.5-fold (0.18 log units) below the measured one, and the stated range covers the measured number.
By their numbers in this assay, from the lowest: compounds 1, 2 and 3 (each within the scatter of the next).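

Placing isopropyl instead of methyl on this saturated chain carbon bound to a carbonyl carbon gives a 1.2-fold higher number from compound 2 to compound 3 (0.09 log units; within the scatter) in this assay, so this enlargement of the chain does not separate the two compounds. Placing 3-carboxy-4-fluorophenyl instead of 4-carboxy-2-chlorophenyl on an oxygen on a saturated carbon gives a 1.6-fold higher number from compound 1 to compound 3 (0.20 log units; within the scatter), so this change does not separate its two compounds either. Nothing measured here accounts for these results. On these data alone, it remains open whether a longer chain, such as hexyl, or an amine at this place would shift the number beyond the scatter.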